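A few compounds are considered here, and "the series" means these few. Any claim that something is new, unique, unknown or untested is made for them only; others in the source may bear on it.

Four compounds share one core and are compared here in an ADME assay on HepG2 cells (Homo sapiens) for cytotoxicity, read by luminescence, CellTiter-Glo and ATP content, with a stated time of 72 h; a lower number here means that less compound is needed, a higher number that more compound is needed for the effect. Compound 1 `c1ccc(Cc2ccc3c(NCCCNCc4ccco4)ccnc3c2)cc1` gives 16000 nM. Compound 2 `COc1ccc(F)cc1CNCCCNc1ccnc2cc(Cc3ccccc3)ccc12` gives 7990 nM, and compound 3 `COc1cccc(CNCCCNc2ccnc3cc(Cc4ccccc4)ccc23)c1O` gives 5720 nM. Among these three numbers compound 2 sits between the other two, yet neither neighbour is clearly separated from it: the step of a 2.0-fold lower number from compound 1 to compound 2 (0.30 log units; within the scatter) and the step of a 1.4-fold lower number from compound 2 to compound 3 (0.15 log units; within the scatter) both lie within the scatter, while only the step of a 2.8-fold lower number from compound 1 to compound 3 (0.45 log units; beyond the scatter) reaches beyond it.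

Compound 4 `COc1ccc(F)cc1CNCCCNc1ccnc2cc(CCc3ccccc3)ccc12` has not yet been measured. It differs from compound 2 in one place: benzyl in place of phenyl on a saturated chain carbon bound to an aromatic carbon. Within the data shown here, every measured step so far altered the group on the saturated chain carbon bound to an amine nitrogen, at the other end of the molecule, and the largest of them was the modest step of a 2.8-fold lower number from compound 1 to compound 3 (0.45 log units; beyond the scatter). Among the measured compounds shown here, no measured step touches the part that changes here, so there is nothing to suggest a shift beyond the scatter, and the step of a 1.0-fold higher number from compound 2 to compound 4 (0.00 log units; within the scatter) is the one expected. Compound 4 is therefore estimated at 8000 nM in this assay, with a likely range from 3500 nM to 18000 nM.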

Compound 4, half-maximal effective concentration: 4240 nM
The estimate for compound 4 lay 1.9-fold (0.28 log units) above the measured number; the measured number falls inside the stated range.
By their numbers in this assay, from the lowest: compounds 4, 3, 2 and 1 (each within the scatter of the next, the first and the last beyond it).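

In this assay, among these compounds, this is the first step read on a saturated chain carbon bound to an aromatic carbon, and benzyl in place of phenyl there gives a 1.9-fold lower number from compound 2 to compound 4 (0.28 log units; within the scatter). The earlier steps shown here all changed the group on a saturated chain carbon bound to an amine nitrogen, so this one shows that the other place can also be altered, here with the longer phenethyl arm, without a shift beyond the scatter. No supporting measurement is available to explain the size of this step.

On these data alone, a single step within the scatter cannot show a trend, so it remains open whether a longer chain, or an amine or a carboxylic acid on this arm, would move the number beyond the scatter. As far as these compounds go, it is also open whether benzyl in place of phenyl would read the same alongside furan-2-yl or 2-hydroxy-3-methoxyphenyl.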